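Methyl for methoxy in a weakly cytotoxic series

The source may hold more compounds than are shown below. What is called first, only, known or untested is meant among the compounds shown, and "the series" means these compounds.

- Compound 1 `O=C1NC(=O)c2c1c1c3cc(O)ccc3[nH]c1c1cccn21`: > 100000 nM (a limit)
- Compound 2 `COc1ccc2[nH]c3c(c4c(c5ccnn53)C(=O)NC4=O)c2c1`: "not determined" (no result reported)

In a functional assay on MCF7 cells (Homo sapiens) for cytotoxicity, read by MTT assay, with a stated time of 72 h (a lower number here means a stronger inhibitor, a higher number a weaker inhibitor), compound 2 has no number and stands at "not determined" (no result reported). For the measured compounds named here, the only other reading belongs to compound 1 and is a limit, not a number: the limit of > 100000 nM in this assay, at which 1 of the 2 values shown sits. Compound 3 `Cc1ccc2[nH]c3c(c4c(c5ccnn53)C(=O)NC4=O)c2c1` is still to be measured. The change methyl in place of methoxy on an aromatic carbon puts methyl in place of methoxy on an aromatic carbon. Going by the values given here, no measured step gives a size here, so only a small step of no firm direction is expected in this assay. This expectation rests on compound 1 alone, with its limit of > 100000 nM. For compound 3 the expected value is 50000 nM, estimated to fall from 10000 nM to 100000 nM.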

Compound 3, half-maximal inhibitory concentration: 9000 nM
Beside the measured number, compound 3's estimate is 5.6-fold (0.74 log units) above it, and the stated range ends above it.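

For the compounds shown here, compound 2 has no number in this assay, and no step from it to compound 3 can be read. The compounds shown leave open what methyl in place of methoxy does in this assay.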